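Ester substituent change at the dihydropyridine core, one step

This account rests on a few compounds, and the source may have more. Where it says the series, first, only, none or still open, it means among the compounds named here.

Measured so far:
- `C#CCCOC(=O)C1=C(C)NC(C)=C(C(=O)OC)C1c1cccc([N+](=O)[O-])c1` compound 1: 31 nM
- `COC(=O)C1=C(C)NC(C)=C(C(=O)OC2C=CCCC2)C1c1cccc([N+](=O)[O-])c1` compound 2: 10 nM
- `COC(=O)C1=C(C)NC(C)=C(C(=O)OCc2ccc(OC)cc2)C1c1cccc([N+](=O)[O-])c1` compound 3: 51 nM

In a functional assay on HEK293 cells for antagonist activity at Voltage-dependent L-type calcium channel subunit alpha-1C (Oryctolagus cuniculus), read by FLIPR (a lower number here means a stronger inhibitor, a higher number a weaker inhibitor), compound 3 gives the highest of the three numbers; compound 1 sits within the scatter of it, while compound 2 is set apart, a 5.1-fold higher number from compound 2 to compound 3 (0.71 log units; beyond the scatter). Compound 4, `COC(=O)C1=C(C)NC(C)=C(C(=O)OCCc2ccc(Cl)cc2)C1c1cccc([N+](=O)[O-])c1`, differs from compound 3 in one place: 4-chlorobenzyl in place of 4-methoxyphenyl on a saturated chain carbon bound to an oxygen next to a carbonyl group. Among the compounds with values here, no measured step swaps exactly these groups, but the ester substituent varies across all three measured compounds, with a 3.1-fold lower number from compound 1 to compound 2 (0.49 log units; beyond the scatter) and a 1.6-fold higher number from compound 1 to compound 3 (0.22 log units; within the scatter), so changes here have moved this assay only modestly. A similar modest shift, if any, is expected here, with the direction uncertain: a 1.5-fold lower number from compound 3 to compound 4 (0.16 log units; within the scatter). Compound 4 is therefore estimated at 35 nM, within a range of 12 nM to 110 nM.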

Compound 4, half-maximal inhibitory concentration: 8 nM
Compound 4: the middle estimate sits 4.4-fold (0.64 log units) above what was measured; measured number below the stated range.
By their numbers in this assay, from the lowest: compounds 4 and 2 (each within the scatter of the next); then compounds 1 and 3 (each within the scatter of the next).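

In this assay an aromatic ring on this ester is not tied to the higher numbers that compound 3 gave: the 2-(4-chlorophenyl)ethyl ester shows a 6.4-fold lower number from compound 3 to compound 4 (0.80 log units; beyond the scatter) and also a 3.9-fold lower number from compound 1 to compound 4 (0.59 log units; beyond the scatter). It cannot be told apart from the cyclohex-2-en-1-yl ester (a 1.3-fold lower number from compound 2 to compound 4 (0.10 log units; within the scatter)), so two very different groups fit equally well here. Nothing available explains this shift. Chain length and ring substituent changed together, so a 2-(4-methoxyphenyl)ethyl ester would be needed to separate them. On these data alone, how an amine on this chain would behave also remains open.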